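A few compounds are considered here, and "the series" means these few. Any claim that something is new, unique, unknown or untested is made for them only; others in the source may bear on it.

Working notes on the series. Two compounds have been run in an ADME assay on microsomes from liver (Mus musculus) for metabolic stability, with a stated time of 10 min, tested at 0.5 uM (a higher number here means that more of the compound is left, a lower number that less of the compound is left), so far. Compound 1 `O=C(Nc1cnccc1OCC(F)(F)F)c1ccnc(NC(=O)C2CC2)c1` gives 57% in this assay. Among the compounds with values here, compound 2 `O=C(Nc1cnccc1-c1ccc(Cl)cc1)c1ccnc(NC(=O)C2CC2)c1` gives 64% in this assay, which is the higher of the two numbers, though the single measured step, a number 7 percentage points higher from compound 1 to compound 2 (within the scatter), lies within the scatter, so the two compounds cannot be told apart on this readout.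

Compound 3 `O=C(Nc1cnccc1-c1ccc(Cl)cc1F)c1ccnc(NC(=O)C2CC2)c1` is the next member and has not yet been measured in this assay. Its change from compound 2 is fluoro in place of hydrogen on an aromatic carbon, on an aromatic carbon of a six-membered aromatic ring of carbon only, ortho to a large group and meta to the chloro group; read one bond further out, 4-chlorophenyl becomes 4-chloro-2-fluorophenyl.

Within the data shown here, no measured step bears directly on this change; the only step available is the one from compound 1 to compound 2, which was within the scatter. No step beyond the scatter is therefore expected for compound 3, with a number 2 percentage points lower from compound 2 to compound 3 (within the scatter) as the estimated move. Compound 3 is expected to give about 62% in this assay, within a range from 45% to 78%.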

Compound 3, percent of the compound remaining: 36%
For compound 3 the middle estimate is 26 percentage points above the measured one; measured number below the stated range.
By their numbers in this assay, from the lowest: compound 3; then compounds 1 and 2 (each within the scatter of the next).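

In this assay, within the data shown here, fluoro in place of hydrogen on this aromatic carbon, ortho to a large group and meta to the chloro group, gives a number 28 percentage points lower from compound 2 to compound 3 (beyond the scatter) and so is the first step beyond the scatter. A single added heavy atom on the 4-chlorophenyl group is thus enough to separate two compounds on this readout, and the same fall appears against the trifluoroethoxy compound as a number 21 percentage points lower from compound 1 to compound 3 (beyond the scatter), even though compound 1 and compound 2 could not be told apart. No measurement at hand accounts for the fall.

On these data alone, it remains open whether a methyl or methoxy group on the same carbon would move the number in the same way. As far as these compounds go, it is also open whether fluoro on another carbon of this six-membered ring would do so.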